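A few compounds are considered here, and "the series" means these few. Any claim that something is new, unique, unknown or untested is made for them only; others in the source may bear on it.

Three compounds have entries in an ADME assay on cells (Erythrocyte, Homo sapiens), read by spectrophotometry and hemolysis, with a stated time of 24 h (a higher number here means a weaker inhibitor, a lower number a stronger inhibitor), and none of them gives a single number. Compound 1 `CC1(C)[N+]([O-])=c2ccc(COc3cccc(C=O)c3)cc2=[N+]1[O-]` reads < 50 uM as its result, which is a limit and not a number. Compound 2 `C=CCNC(=S)N/N=C/c1cccc(OCc2ccc3no[n+]([O-])c3c2)c1` has the entry "nd(insoluble)" (no result reported) in this assay as its outcome. Compound 3 `CC1(C)[N+]([O-])=c2ccc(COc3ccc(/C=N/NC(N)=S)cc3)cc2=[N+]1[O-]` has the entry "nd(insoluble)" (no result reported) in this assay as well, so it offers no number from which to measure a step. Compound 4 `CC1(C)[N+]([O-])=c2ccc(COc3ccc(/C=N/NC(N)=O)cc3)cc2=[N+]1[O-]` is still to be tested. The change is a group of 3 heavy atoms (1 carbon, 1 nitrogen, 1 oxygen; no ring) in place of a group of 3 heavy atoms (1 carbon, 1 nitrogen, 1 sulfur; no ring), on an amine nitrogen and it places carbamoyl on an amine nitrogen. For the measured compounds named here, with no starting number, no step of any particular size or direction can be expected in this assay beyond the scatter. In this assay the expected value for compound 4 is 25 uM with an estimated range of 5 uM to 100 uM as the likely span.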

Compound 4, concentration for 50% inhibition: > 200 uM
Compound 4 ended at the assay's limit; the forecaster's own chance of this, stated with the estimate: 40%; at least 8.0-fold (0.90 log units) between middle value and limit.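

In this assay compound 4 gives > 200 uM, which is a limit. The entry for compound 3 carries no number, so no step can be read from compound 3 to compound 4. The compounds shown leave open how far carbamoyl in place of the sulfur-bearing group shifts the value in this assay.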